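A few compounds are considered here, and "the series" means these few. Any claim that something is new, unique, unknown or untested is made for them only; others in the source may bear on it.

Compound 1 `CC(=O)Oc1ccc(N2C(=O)/C(=C/N3N=C(c4ccccc4)CC3c3ccccc3O)SC2=S)cc1` sets the reference point: in a functional assay on SK-OV-3 cells (Homo sapiens) for antiproliferative activity, read by MTT assay, with a stated time of 72 h (on this read-out lower numbers stand for stronger inhibition and higher numbers for weaker inhibition), compound 1 gives 244 nM. Compound 2 `CC(=O)Oc1ccc(N2C(=O)/C(=C/N3N=C(c4ccc5ccccc5c4)CC3c3ccccc3O)SC2=S)cc1` differs from it only by carrying naphthalen-2-yl in place of phenyl on the carbon with a double bond to nitrogen. For compound 2 the assay gives only a limit, > 10000 nM, so its true value is not known (the limit of > 10000 nM in this assay, at which 1 of the 2 values shown sits). The step is an at least 40-fold higher number from compound 1 to compound 2 (1.61 log units; beyond the scatter), and compound 2 stands at the weak end of the two measured compounds.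

Compound 3 `COc1ccc(C2CC(c3ccc4ccccc4c3)=NN2/C=C2\SC(=S)N(c3ccc(OC(C)=O)cc3)C2=O)cc1` keeps the naphthalen-2-yl group of compound 2 and changes a different place: 4-methoxyphenyl in place of 2-hydroxyphenyl on a saturated ring carbon. Within the data shown here, no measured step touches this saturated ring carbon; the single measured step, the one from compound 1 to compound 2, concerns the carbon with the double bond to nitrogen and therefore says nothing about exchanging the aryl group on the saturated ring carbon. What is known of compound 2 is a limit, so the starting point itself is uncertain. Compound 3 is expected to remain near that limit, with the step that the limit leaves unreadable from compound 2 to compound 3 read as no step beyond the scatter. The estimate for compound 3 is 15000 nM, ranging from 3000 nM to 60000 nM.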

Compound 3, half-maximal inhibitory concentration: 1100 nM
Compound 3: the middle estimate sits 14-fold (1.13 log units) above what was measured; the whole stated range lies above it.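

Exchanging 2-hydroxyphenyl for 4-methoxyphenyl on the saturated ring carbon gives an at least 9.0-fold lower number from compound 2 to compound 3 (0.95 log units; beyond the scatter) in this assay, so the aryl group at this place bears on the read-out even when naphthalen-2-yl is present. Compound 3 also carries naphthalen-2-yl, which shows that this group does not by itself hold a compound at the limit of the assay. The true size of the step cannot be given, because compound 2 is known only through a limit: the limit of > 10000 nM in this assay, at which 1 of the 3 values shown sits.

The change from 2-hydroxyphenyl to 4-methoxyphenyl alters both the group on the aryl ring and where it stands, so the compounds shown cannot separate these two changes; 2-methoxyphenyl or 4-hydroxyphenyl on the saturated ring carbon would tell them apart, and a plain phenyl there would show what either group contributes. Going by these compounds, it also remains open whether 4-methoxyphenyl would give a similar result with phenyl rather than naphthalen-2-yl on the carbon with a double bond to nitrogen, as in compound 1.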